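A few compounds are considered here, and "the series" means these few. Any claim that something is new, unique, unknown or untested is made for them only; others in the source may bear on it.

Measured so far in a functional assay on HCT-116 cells (Homo sapiens) for inhibition, read by sulforhodamine B assay, with a stated time of 48 h, tested at 50 uM; on this read-out lower numbers stand for less inhibition of growth and higher numbers for more inhibition of growth at the one concentration tested:
- compound 1 `COc1cc(/C=C/C(=O)/C=C/c2cccc3ccccc23)ccc1OCc1cn(CCCOc2cc(=O)oc3ccccc23)nn1`: 66%
- compound 2 `COc1ccc(/C=C/C(=O)/C=C/c2ccc(OCc3cn(CCCCCOc4cc(=O)oc5ccccc45)nn3)c(OC)c2)cc1OC`: 45%
- compound 3 `COc1cc(/C=C/C(=O)/C=C/c2ccco2)ccc1OCc1cn(CCCOc2cc(=O)oc3ccccc23)nn1`: 51%

Among the compounds with values here, compound 3 lies within the scatter of compound 2 and well short of compound 1, the gap to which is the one step below. The next structure is compound 4 `COc1ccccc1/C=C/C(=O)/C=C/c1ccc(OCc2cn(CCCOc3cc(=O)oc4ccccc34)nn2)c(OC)c1`, which carries 2-methoxyphenyl in place of furan-2-yl on a double-bonded chain carbon bound to a double-bonded chain carbon.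

Within the data shown here, one measured step bears on this change. At the same place and with the same chain, the read-out gives a number 15 percentage points lower from compound 1 to compound 3 (beyond the scatter), for furan-2-yl in place of naphthalen-1-yl. This shows that the group at this place can move the read-out by a modest amount. Compound 2 differs from compound 3 in more than one place, so it offers no clean comparison. Among the measured compounds shown here, no measured compound carries 2-methoxyphenyl, so the direction rests on a single step and is weakly supported.

A small rise in this assay is expected, staying inside the span set by that step. The estimated step is a number 5 percentage points higher from compound 3 to compound 4 (within the scatter). For compound 4 the expected value is 56%, with an estimated range of 43% to 69%.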

Compound 4, percent growth inhibition at one concentration: 53%
For compound 4 the middle estimate is 3 percentage points above the measured one; the measured number falls inside the stated range.
By their numbers in this assay, from the lowest: compounds 2, 3 and 4 (each within the scatter of the next); then compound 1.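

In this assay the change to 2-methoxyphenyl on a double-bonded chain carbon bound to a double-bonded chain carbon gives a number 2 percentage points higher from compound 3 to compound 4 (within the scatter) and so does not separate this group from furan-2-yl, even though the six-membered aromatic ring of carbon only and its extra heavy atoms replace a five-membered aromatic ring with 1 hetero atom. Measured against naphthalen-1-yl at the same place, the read-out gives a number 13 percentage points lower from compound 1 to compound 4 (beyond the scatter) and thus adds a second replacement of naphthalen-1-yl that ends beyond the scatter, so among compound 1, compound 3 and compound 4 only the naphthalen-1-yl group stands apart. Nothing at hand gives a reason for the gap between naphthalen-1-yl and the other two groups.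

As far as these compounds go, how an aliphatic amine, a carboxylic acid or a 2-hydroxyphenyl group would read at this place remains open, as does whether the order seen at the one concentration tested would hold across a range of concentrations. Compound 2 differs from the others in more than one place, which leaves the contribution of its longer chain unresolved.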